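A few compounds are considered here, and "the series" means these few. Any claim that something is new, unique, unknown or untested is made for them only; others in the source may bear on it.

In a functional assay on MCF7 cells (Homo sapiens) for cytotoxicity, read by MTT assay, with a stated time of 96 h (a higher number here means a weaker inhibitor, a lower number a stronger inhibitor), three compounds built on one shared core have been measured. Compound 1 `COc1cc(C(=O)c2cn(-c3ccccc3)cc2-c2ccccc2Cl)cc(OC)c1OC`, with 2-chlorophenyl, gives 76 nM. Compound 2 `COc1cc(C(=O)c2cn(-c3ccccc3)cc2-c2cccc(Cl)c2)cc(OC)c1OC`, with 3-chlorophenyl, gives 540 nM. Compound 3 `COc1cc(C(=O)c2cn(-c3ccccc3)cc2-c2ccccc2[N+](=O)[O-])cc(OC)c1OC`, with 2-nitrophenyl, gives 49 nM, which places it at the low end of these numbers, a position it shares with compound 1. The data show a 1.6-fold lower number from compound 1 to compound 3 (0.19 log units; within the scatter), whereas they show a large gap in an 11-fold lower number from compound 2 to compound 3 (1.04 log units; beyond the scatter).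

Compound 4 `COc1cccc(-c2cn(-c3ccccc3)cc2C(=O)c2cc(OC)c(OC)c(OC)c2)c1` has 3-methoxyphenyl in place of 2-nitrophenyl on an aromatic carbon. Among the measured compounds shown here, no compound with a methoxy group has been measured, so the evidence is indirect. The nearest guide is the swap of 2-chlorophenyl for 3-chlorophenyl, which gave a 7.1-fold higher number from compound 1 to compound 2 (0.85 log units; beyond the scatter). A modest step towards a higher number, meaning a weaker inhibitor, is therefore expected in this assay, and the estimated change is a 5.1-fold higher number from compound 3 to compound 4 (0.71 log units; beyond the scatter). For compound 4 the estimated value is 250 nM, with an expected range of 60 nM to 1000 nM.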

Compound 4, half-maximal inhibitory concentration: 180 nM
The estimate for compound 4 lay 1.4-fold (0.14 log units) above the measured number; measured number inside the range.
By their numbers in this assay, from the lowest: compounds 3 and 1 (each within the scatter of the next); then compound 4; then compound 2.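

Keeping the group's place on the phenyl ring fixed but swapping 3-chlorophenyl for 3-methoxyphenyl gives a 3.0-fold lower number from compound 2 to compound 4 (0.48 log units; beyond the scatter), so the identity of the group matters at this position and not only where it sits on that ring. Even so, 3-methoxyphenyl does not reach the numbers of the 2-substituted phenyl groups, with a 3.7-fold higher number from compound 3 to compound 4 (0.57 log units; beyond the scatter) and a 2.4-fold higher number from compound 1 to compound 4 (0.37 log units; beyond the scatter), although each of these two steps changes both the group and its place on the ring, and the two changes cannot be told apart. Nothing in the data given explains these differences.

Still open, as far as these compounds go, is how 2-methoxyphenyl would compare, since it would keep the methoxy group and change only its place on the ring. Also open, from the compounds shown here alone, is what an amine or a carboxylic acid on this phenyl ring would do.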